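Methyl on a Ring Oxygen: Expected Outcome in Cell Assay

The source may hold more compounds than are shown below. What is called first, only, known or untested is meant among the compounds shown, and "the series" means these compounds.

Of the compounds shown here, three of closely related build have been tested in an ADME assay on WS1 cells (Homo sapiens) for inhibition, with a stated time of 48 h; a higher number here means a weaker inhibitor, a lower number a stronger inhibitor. Compound 1 `COc1ccc2c(=O)cc(/C=C/[S+](C)[O-])oc2c1O` carries a hydroxy group on an aromatic ring. In this assay compound 1 gives only a limit of the assay, > 10000 nM. Compound 2 `COc1ccc2c(=O)cc(/C=C/[S+](C)[O-])oc2c1OC` differs from compound 1 by methyl in place of hydrogen on an oxygen on an aromatic ring. In this assay compound 2 also reaches only a limit, > 10000 nM. The step that the two limits leave unreadable from compound 1 to compound 2 cannot be read because both ends sit at the limit of > 10000 nM in this assay, at which 3 of the 3 values shown sit.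

Compound 3 `C[S+]([O-])/C=C/c1cc(=O)c2cc(O)ccc2o1` is built on a different core; the difference between the two cores is not broken down here. In this assay compound 3 likewise returns only a limit, > 10000 nM.

Compound 4 `COc1ccc2oc(/C=C/[S+](C)[O-])cc(=O)c2c1` has not yet been measured in this assay. It differs from compound 3 by methyl in place of hydrogen on an oxygen on an aromatic ring, the same change that separates compound 1 from compound 2. With compound 3 already at a limit, and with the same change giving no readable shift between compound 1 and compound 2, the step that the limit leaves unreadable from compound 3 to compound 4 is expected to be small or not readable at all. Compound 4 is therefore estimated at 25000 nM, with a plausible range from 8000 nM to 150000 nM, and most probably the assay will again report only a limit rather than a number.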

Compound 4, half-maximal inhibitory concentration: 6000 nM
Compound 4: middle estimate off by 4.2-fold (0.62 log units), on the high side; the whole stated range lies above it.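

In this assay, among the compounds shown here, methyl in place of hydrogen on an oxygen on an aromatic ring gives an at least 1.6-fold lower number from compound 3 to compound 4 (0.22 log units; that floor lies within the scatter), and compound 4 is the only one of the four compounds to return a number rather than a limit. The same change on the core of compound 1 cannot be read, because both ends of that step sit at a limit, so the two cores cannot be compared step against step: the limit of > 10000 nM in this assay, at which 3 of the 4 values shown sit. This shows that, on the core of compound 3, the methoxy compound reaches a measurable value, but it does not show that the change carries over from one core to the other, nor how large the step really is, as the true value of compound 3 lies hidden behind its limit and the floor of the step lies within the scatter.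

The compounds shown leave open whether a larger group on the same oxygen, such as ethyl or a longer chain, would go on to give a lower number on the core of compound 3. They also leave open what an amine or a carboxylic acid in place of the methoxy group would do on either core.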